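The compounds below may be only part of what the source reports. "The series", "measured", "known", "first", "only" and "open" are said of these compounds alone.

Measured so far, each entry a limit and not a number:
compound 1 `Cc1ccc(-c2c3c(nc(C)c2C(OC(C)(C)C)C(=O)O)CCN(CCCC2CCCC2)C3)cc1` gives > 40000 nM
compound 2 `Cc1ccc(-c2c3c(nc(C)c2[C@H](OC(C)(C)C)C(=O)O)CCN(CCCc2ccccc2)C3)cc1` gives > 40000 nM
compound 3 `Cc1nc2c(c(-c3cc(F)c4c(c3C)CCCO4)c1[C@H](OC(C)(C)C)C(=O)O)CN(CCCc1ccc(F)cc1)CC2` gives > 40000 nM

In an ADME assay on MT2 cells (Homo sapiens) for cytotoxicity, read by XTT assay, with a stated time of 4 days (a higher number here means that more compound is tolerated, a lower number that less compound is tolerated), compound 2 gives > 40000 nM as a limit of the assay and not a number. Its standing in the series is therefore not a rank: what the series shows is the limit of > 40000 nM in this assay, at which 3 of the 3 values shown sit, and nothing finer.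

Compound 4 `Cc1ccc(-c2c3c(nc(C)c2[C@H](OC(C)(C)C)C(=O)O)CCN(Cc2ccccc2)C3)cc1` carries phenyl in place of phenethyl on a saturated chain carbon bound to an amine nitrogen in a ring, and the same difference, cut one bond further out, reads 3-phenylpropyl to benzyl.

Among the compounds with values here, no step between measured compounds is available to size this change. The a number no higher from compound 2 to compound 4 (the limit leaves the size open) is expected to be none beyond the scatter, in either direction. That expectation rests on compound 2 with > 40000 nM as its limit. Compound 4 is estimated at 40000 nM with an expected range from 15000 nM to 60000 nM and a good chance of reading as a limit again.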

Compound 4, half-maximal cytotoxic concentration: > 40000 nM
Compound 4 was reported as a limit; the forecaster's own chance of this, stated with the estimate: 75%; the middle value sits exactly at the limit.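

Compound 2 and compound 4 each read as a limit and not a number in this assay, so no step between them can be read: the limit of > 40000 nM in this assay, at which 4 of the 4 values shown sit.

The actual half-maximal cytotoxic concentration of each compound shown, and whether phenyl in place of phenethyl shifts it, remain open.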